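The source may hold more compounds than are shown below. What is called first, only, known or untested is meant among the compounds shown, and "the series" means these compounds.

Working notes on the series. Compound 1 `O=C(Nc1cccc(-c2ccco2)c1)C1CCCN(C(=O)c2cc(C(F)(F)F)cc(C(F)(F)F)c2)C1`, compound 2 `O=C(Nc1cccc([N+](=O)[O-])c1)C1CCCN(C(=O)c2cc(C(F)(F)F)cc(C(F)(F)F)c2)C1` and compound 3 `CC(=O)c1cccc(NC(=O)C2CCCN(C(=O)c3cc(C(F)(F)F)cc(C(F)(F)F)c3)C2)c1` share one core and differ only in the group carried on one aromatic carbon. In an ADME assay on PC-3 cells (Homo sapiens) for cytotoxicity, read by WST assay, tested at 100 uM (on this read-out higher numbers stand for more inhibition at the one concentration tested (going by the name of the read-out) and lower numbers for less inhibition), compound 1 gives 0%, compound 2 gives 9% and compound 3 gives 0%. Compound 3 thus stands level with compound 1 at the digits shown, the two together the lowest of the three numbers; the step of no change at the digits printed from compound 1 to compound 3 (within the scatter) lies within the scatter, as does a number 9 percentage points lower from compound 2 to compound 3 (within the scatter), and the step of a number 9 percentage points higher from compound 1 to compound 2 (within the scatter) as well. None of the three exchanges at this aromatic carbon has moved the read-out beyond the scatter.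

Compound 4 `Cn1cnnc1-c1cccc(NC(=O)C2CCCN(C(=O)c3cc(C(F)(F)F)cc(C(F)(F)F)c3)C2)c1` is the next member, with the change (4-methyl-4H-1,2,4-triazol-3-yl in place of acetyl on an aromatic carbon). The same aromatic carbon is the place of all three measured exchanges, so those three steps are the ones that bear on it, and each was within the scatter. On that basis no shift beyond the scatter is expected in this assay, in either direction. The step of a number 3 percentage points higher from compound 3 to compound 4 (within the scatter) is therefore estimated to be flat. Compound 4 is expected to give 3% in this assay, with a range from 0% to 15%.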

Compound 4, a percentage reported as inhibition, at one concentration (the size of the read-out at that concentration, not a potency): 0%
Compound 4: middle estimate off by 3 percentage points, on the high side, within the range that was stated.
By their numbers in this assay, from the lowest: compounds 1, 3, 4 and 2 (each within the scatter of the next).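

With the 4-methyl-4H-1,2,4-triazol-3-yl group, a five-membered aromatic ring with 3 hetero atoms now joins furan-2-yl, nitro and acetyl at this aromatic carbon, and this assay still shows no step beyond the scatter: no change at the digits printed from compound 3 to compound 4 (within the scatter) stands alongside no change at the digits printed from compound 1 to compound 4 (within the scatter) and a number 9 percentage points lower from compound 2 to compound 4 (within the scatter) in the same way. For the compounds shown here, all exchanges at this place now lie within the scatter, and this holds across a wider range of group size and hydrogen-bond acceptor count than the earlier compounds covered. No measurement at hand offers a reason for this flat picture.

On these data alone, whether an amine or a carboxylic acid on this aromatic carbon would move the read-out beyond the scatter remains open. So does the outcome of replacing a trifluoromethyl group on the other aromatic ring with a chlorine or a methoxy group.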